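The compounds below may be only part of what the source reports. "The series", "measured", "known", "first", "only" and "open" are said of these compounds alone.

Compound 1 `CSc1ccccc1Nc1nc2c(Nc3ccc(C(F)(F)F)cc3)ncnc2s1`: 26 nM
Compound 2 `Cc1nc(Nc2ccc(C(F)(F)F)c(Cl)c2)c2nc(Nc3c(Cl)cccc3Cl)sc2n1`: 2 nM

In a functional assay on HEK293 cells for antagonist activity at transient receptor potential cation channel subfamily V member 1 (Rattus norvegicus), read by calcium flux (on this read-out higher numbers stand for weaker inhibition and lower numbers for stronger inhibition), compound 2 gives 2 nM, the lower of the two numbers; compound 1 sits higher, by a gap beyond the usual scatter. Compound 3 `CS(=O)(=O)c1nc(Nc2ccc(C(F)(F)F)c(Cl)c2)c2nc(Nc3c(Cl)cccc3Cl)sc2n1` differs from compound 2 in one place: methylsulfonyl in place of methyl on an aromatic carbon, at a position between two ring nitrogen atoms of the shared core. For the measured compounds named here, no measured pair shows this change, so its effect here is unknown; a modest weakening is expected, a 3.0-fold higher number from compound 2 to compound 3 (0.48 log units; beyond the scatter). Compound 3 is therefore estimated at 6 nM, with a range from 1.5 nM to 40 nM.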

Compound 3, half-maximal inhibitory concentration: 77 nM
The estimate for compound 3 lay 13-fold (1.11 log units) below the measured number; the measured number lies above the stated range.
By their numbers in this assay, from the lowest: compound 2; then compound 1; then compound 3.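

In this assay, placing methylsulfonyl instead of methyl on this aromatic carbon, between two ring nitrogen atoms, gives a 39-fold higher number from compound 2 to compound 3 (1.59 log units; beyond the scatter) and so a clearly weaker inhibitor. For the compounds shown here, this is the first sign that the group at this position of the shared core strongly affects the read-out. Nothing at hand explains why the number rises. On these data alone, what remains open is how an amine or a methoxy group at this position would read, and whether any group here could give a lower number than methyl.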